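This account rests on a few compounds, and the source may have more. Where it says the series, first, only, none or still open, it means among the compounds named here.

In a functional assay on DU-145 cells (Homo sapiens) for inhibition, read by trypan blue exclusion, with a stated time of 72 h (a lower number here means a stronger inhibitor, a higher number a weaker inhibitor), two compounds with the same core have been measured so far. Compound 1 `Cn1c(=O)c(S(=O)(=O)c2ccc(C(=O)O)cc2)cc2cnc(Nc3ccc4[nH]ccc4c3)nc21`, which carries 4-carboxyphenyl on a sulfonyl sulfur, gives 10000 nM. Compound 2 `Cn1c(=O)c(S(=O)(=O)c2ccc([N+](=O)[O-])cc2F)cc2cnc(Nc3ccc4[nH]ccc4c3)nc21`, which carries 2-fluoro-4-nitrophenyl in that place, gives 400 nM, the lower of the two numbers and so the stronger inhibitor of the pair.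

Compound 3 `Cn1c(=O)c(S(=O)(=O)c2ccc(F)cc2N)cc2cnc(Nc3ccc4[nH]ccc4c3)nc21` changes the same group: 2-amino-4-fluorophenyl in place of 2-fluoro-4-nitrophenyl on a sulfonyl sulfur. Put simply, 2-amino-4-fluorophenyl takes the place of 2-fluoro-4-nitrophenyl on the sulfonyl sulfur.

Among the compounds with values here, only one measured step bears on this change. That step, a 25-fold lower number from compound 1 to compound 2 (1.40 log units; beyond the scatter), shows that the group on the sulfonyl sulfur can matter a great deal in this assay. Yet it involved 4-carboxyphenyl, a group that compound 3 does not carry, so it offers only a loose guide. Within the data shown here, no measured pair shows what this particular exchange does. A small move towards a higher number is therefore expected, with the estimated step of a 1.3-fold higher number from compound 2 to compound 3 (0.10 log units; within the scatter) staying within the scatter. For compound 3, the estimated value is 500 nM, with an expected range from 120 nM to 2500 nM.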

Compound 3, half-maximal inhibitory concentration: 3000 nM
For compound 3 the middle estimate is 6.0-fold (0.78 log units) below the measured one; measured number above the stated range.
By their numbers in this assay, from the lowest: compound 2; then compound 3; then compound 1.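

In this assay there is a 7.5-fold higher number from compound 2 to compound 3 (0.88 log units; beyond the scatter) even though both groups keep one six-membered aromatic ring and carry no net charge. The position on the sulfonyl sulfur is therefore sensitive to more than the loss of the 4-carboxyphenyl group seen earlier: an exchange between two substituted phenyl groups, with a hydrogen-bond donor count going from none to one, is also enough to move the number beyond the scatter. Alongside this stands a 3.3-fold lower number from compound 1 to compound 3 (0.52 log units; beyond the scatter) and compound 3 thus falls between the other two, giving three clearly separated numbers at this one position, while nothing available here explains the size of either step.

The compounds shown leave open which part of the exchange counts: in one step the nitro group leaves, an amino group enters and the fluorine appears at a different printed ring number. A 2-aminophenyl group without fluorine, or a 4-fluorophenyl group without the amino group, would begin to pull these changes apart on the same core.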